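From 2-fluoro-3-methylphenyl to 3-methylpyridin-4-yl

The compounds below may be only part of what the source reports. "The series", "measured", "known", "first", "only" and "open" are said of these compounds alone.

Among the compounds with values here, in a physicochemical assay for lipophilicity, read by HPLC, at pH 7.5 (a lower number here means a more polar compound, a higher number a more lipophilic compound), compound 2 `CC[C@@H](Nc1c(C#N)c(-c2ccc(-c3cccc(C)c3F)cc2)nc2cnccc12)C(N)=O` gives 3, the higher of the two numbers so far, while compound 1 `CC[C@@H](Nc1c(C#N)c(-c2ccc(-c3ncccc3C)cc2)nc2cnccc12)C(N)=O` gives 2, which lies beyond the scatter from it.

Compound 3 `CC[C@@H](Nc1c(C#N)c(-c2ccc(-c3ccncc3C)cc2)nc2cnccc12)C(N)=O` differs from compound 2 by 3-methylpyridin-4-yl in place of 2-fluoro-3-methylphenyl on an aromatic carbon, with 3-methylpyridin-4-yl in place of 2-fluoro-3-methylphenyl on an aromatic carbon, para to a large group.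

Within the data shown here, one measured step bears on this, a number 1.00 log units higher from compound 1 to compound 2 (beyond the scatter), a modest one, with 2-fluoro-3-methylphenyl in place of 3-methylpyridin-2-yl. Among the measured compounds shown here, the new change runs the opposite way, from the phenyl to a pyridine, but no measured compound carries 3-methylpyridin-4-yl, so the size remains uncertain.

The expected step is a number 1.10 log units lower from compound 2 to compound 3 (beyond the scatter) in this assay, downward and of similar size, beyond the scatter.

For compound 3 the estimated value is 1.9, with an expected range from 1.4 to 2.5 for this reading.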

Compound 3, distribution coefficient: 2
Beside the measured number, compound 3's estimate is 0.10 log units below it, and the stated range covers the measured number.
By their numbers in this assay, from the lowest: compounds 1 and 3 (each within the scatter of the next); then compound 2.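

In this assay the step of a number 1.00 log units lower from compound 2 to compound 3 (beyond the scatter) shows that the gap between the 2-fluoro-3-methylphenyl compound and a pyridine is not confined to 3-methylpyridin-2-yl, as 3-methylpyridin-4-yl on the same aromatic carbon, para to a large group, also reads lower. The step of no change at the digits printed from compound 1 to compound 3 (within the scatter) leaves the two methylpyridinyl groups unseparated in this assay, so within this small set the distinction lies between the phenyl group and either pyridine, not between the two pyridines. No measured property of these compounds accounts for either step.

This change removes fluorine and brings in a ring nitrogen together, so a plain 3-methylphenyl group would be needed to part the two. From the compounds shown here alone, how an amine or a carboxylic acid on this ring would read in this assay remains open.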